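Cytotoxicity notes: trimming the piperazine side chain of compound 1

The source may hold more compounds than are shown below. What is called first, only, known or untested is meant among the compounds shown, and "the series" means these compounds.

Of the compounds shown here, two have been read in an ADME assay on MDBK cells (Bos taurus) for cytotoxicity, read by MTT assay, with a stated time of 96 h; on this read-out lower numbers stand for higher toxicity in this test and higher numbers for lower toxicity in this test. Compound 1 `CN1CCN(CC(=O)Nc2ccc(-c3nc4cc(C(F)(F)F)ccc4n3C)cc2)CC1` gives 44000 nM in this assay, the higher of the two numbers and thus the less toxic of the pair. Compound 2 `COc1ccc(-c2nc3cc(Cl)c(Cl)cc3[nH]2)cc1`, which carries a different core substitution pattern and a methoxy group rather than the amide-bearing chain, gives 2500 nM in this assay; the gap between compound 2 and compound 1 lies beyond the usual scatter.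

The next compound, compound 3 `CCC(=O)Nc1ccc(-c2nc3cc(C(F)(F)F)ccc3n2C)cc1`, is still to be measured in this assay. It differs from compound 1 in one place: methyl in place of 4-methylpiperazin-1-yl on a saturated chain carbon bound to a carbonyl carbon. The whole side chain thus shrinks from ((4-methylpiperazin-1-yl)methyl)carbonyl to propanoyl, while the core and its trifluoromethyl group stay as in compound 1.

Among the measured compounds shown here, no measured pair here isolates this change, so its size cannot be read from the data. The step from compound 1 to compound 3 in this assay is expected to be modest, tending toward a somewhat lower number, a 1.5-fold lower number from compound 1 to compound 3 (0.17 log units; within the scatter), and may well fall within the scatter. Compound 3 is accordingly expected at about 30000 nM in this assay, with a range from 10000 nM to 90000 nM.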

Compound 3, half-maximal cytotoxic concentration: > 100000 nM
Compound 3 ended at the assay's limit; the forecaster's own chance of this, stated with the estimate: 25%; at least 3.3-fold (0.52 log units) between middle value and limit.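

Compound 3 reads > 100000 nM in this assay, and this is a limit of the assay, not a number. At the saturated chain carbon bound to a carbonyl carbon, methyl in place of 4-methylpiperazin-1-yl gives an at least 2.2-fold higher number from compound 1 to compound 3 (0.35 log units; beyond the scatter), so in this pair the 4-methylpiperazin-1-yl group is not needed to keep the number high, and removing it moves the read-out toward lower toxicity in this test rather than higher. The step therefore gives only a minimum size, and how far compound 3 truly lies from compound 1 cannot be read: the limit of > 100000 nM in this assay, at which 1 of the 3 values shown sits.

This single pair does not show whether the step follows from losing the whole ring or from losing its amine nitrogens, and a dimethylamino or morpholin-4-yl group on the same chain carbon would separate those two readings. It also leaves open how a longer chain in place of propanoyl, or a carboxylic acid at the end of that chain, would read on the same core in this assay.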